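Compound 2 to compound 3: replacing the aryl group

A few compounds are considered here, and "the series" means these few. Any claim that something is new, unique, unknown or untested is made for them only; others in the source may bear on it.

In a functional assay on A549 cells (Homo sapiens) for antiproliferative activity, read by MTT assay (on this read-out lower numbers stand for stronger inhibition and higher numbers for weaker inhibition), compound 1 `COc1cc2c(Oc3ccc(NC(=O)Nc4ccccc4F)cc3)ccnc2cc1OCCCCCCC(=O)NO` gives 870 nM, and compound 2 `COc1cc2c(Oc3ccc(NC(=O)Nc4ccc(Cl)c(C(F)(F)F)c4)cc3)ccnc2cc1OCCCCCCC(=O)NO` gives 5020 nM. Compound 2 therefore holds the higher of the two numbers, which means the weaker inhibition. Compound 3 `COc1cc2c(Oc3ccc(NC(=O)Nc4ccc(C)cc4C)cc3)ccnc2cc1OCCCCCCC(=O)NO` keeps the rest of compound 2 and changes one group, with 2,4-dimethylphenyl in place of 4-chloro-3-(trifluoromethyl)phenyl on an amide-type nitrogen. Among the measured compounds shown here, only one measured step bears on this change: a 5.8-fold higher number from compound 1 to compound 2 (0.76 log units; beyond the scatter), where 4-chloro-3-(trifluoromethyl)phenyl stands in place of 2-fluorophenyl at the same nitrogen. The group that leaves is thus the one associated with the higher number, and a modest step toward a lower number is expected in this assay, undoing part of a 5.8-fold higher number from compound 1 to compound 2 (0.76 log units; beyond the scatter). For the measured compounds named here, this is a thin basis, since no measured compound carries the 2,4-dimethylphenyl group, so the range stays wide. The expected change is a 2.8-fold lower number from compound 2 to compound 3 (0.45 log units; beyond the scatter). For compound 3 the estimated value is 1800 nM, with an expected range from 650 nM to 5000 nM.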

Compound 3, half-maximal inhibitory concentration: 5490 nM
Estimate against measurement, compound 3: 3.1-fold (0.48 log units) below; measured number outside the range, above it.
By their numbers in this assay, from the lowest: compound 1; then compounds 2 and 3 (each within the scatter of the next).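

In this assay the exchange of 4-chloro-3-(trifluoromethyl)phenyl for 2,4-dimethylphenyl on the amide-type nitrogen gives a 1.1-fold higher number from compound 2 to compound 3 (0.04 log units; within the scatter), so at this position two aryl groups with entirely different substituents read alike. The 2-fluorophenyl group of compound 1 now stands apart from both, since a 6.3-fold higher number from compound 1 to compound 3 (0.80 log units; beyond the scatter) sits alongside the earlier 5.8-fold higher number from compound 1 to compound 2 (0.76 log units; beyond the scatter), and the higher number therefore does not belong to the 4-chloro-3-(trifluoromethyl)phenyl group alone. Nothing at hand gives a measured reason for this outcome.

The three compounds leave open whether the lower number of compound 1 depends on the fluorine atom itself or would also appear with other small groups on the ring, a question that a plain phenyl, a 2-chlorophenyl or a 2-methylphenyl group at the same nitrogen would address. They also leave open whether the 4-fluorophenyl group would read with compound 1 or with compounds 2 and 3, and so whether the placing of a single fluorine matters in this assay's read-out.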